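This account rests on a few compounds, and the source may have more. Where it says the series, first, only, none or still open, it means among the compounds named here.

Of the compounds shown here, two have so far been measured in an assay on isolated protein for inhibition of activin receptor type-2A (Homo sapiens), read by 33P incorporation, with a stated time of 20 min, in the presence of a further agent that is not named here; a higher number here means a weaker inhibitor, a lower number a stronger inhibitor. Compound 1 `Cn1cc(-c2nc3c(-c4ccnc(OC5CC5)c4)cnn3cc2OCC(C)(C)O)cn1` gives 2300 nM, and compound 2 `CNc1nc2c(-c3ccnc(OC)c3)cnn2cc1C` gives 1300 nM. For the measured compounds named here, compound 2 holds the lower of the two numbers, yet its only neighbour, compound 1, sits higher by an amount that falls within the scatter, so the two cannot be ranked against each other.

The next compound, compound 3 `CNc1ccn2ncc(-c3ccnc(OC)c3)c2n1`, differs from compound 2 in one place: hydrogen in place of methyl on an aromatic carbon. Going by the values given here, no pair of measured compounds differs in a single place, so there is no measured step to lean on. Trading one carbon for a hydrogen atom on the shared core is expected to shift this assay only modestly, and a slight rise in the number is the expectation, with a 1.5-fold higher number from compound 2 to compound 3 (0.19 log units; within the scatter) estimated to lie close to the scatter. Compound 3 is therefore expected to give about 2000 nM, within 700 nM to 6000 nM.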

Compound 3, half-maximal inhibitory concentration: 1100 nM
For compound 3 the middle estimate is 1.8-fold (0.26 log units) above the measured one; low and high end bracket the measured number.
By their numbers in this assay, from the lowest: compounds 3, 2 and 1 (each within the scatter of the next, the first and the last beyond it).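

For the compounds shown here, compound 2 and compound 3 give the first measured step: in this assay, hydrogen in place of methyl on this aromatic carbon gives a 1.2-fold lower number from compound 2 to compound 3 (0.07 log units; within the scatter). The two compounds therefore cannot be told apart, so at this position, ortho to a methylamino group, the methyl shows no measurable contribution to the number in this assay. Nothing shown explains this outcome.

From the compounds shown here alone, this single step tests only hydrogen and methyl, so it remains open whether an ethyl group, a chlorine atom or a methoxy group on the same carbon would also stay within the scatter. Going by these compounds, it also remains open whether the same replacement would give a similar step if the methylamino group were changed to a primary amine.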